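Swapping cyclohexyl for 4-chlorophenyl on an amide-type nitrogen

The source may report more compounds than this note shows. Statements on the series, on what has been measured and on what is new or still open speak of the compounds shown alone.

- Compound 1 `O=C(Nc1ccc(Nc2nccc(Nc3ccccc3)n2)cc1)Nc1ccc(Cl)c(C(F)(F)F)c1`: > 50000 nM (a limit, not a number)
- Compound 2 `O=C(Nc1ccc(Nc2nccc(NC3CCCC3)n2)cc1)NC1CCCCC1`: 1090 nM

Among the measured compounds shown here, in a functional assay on HCT-116 cells (Homo sapiens) for antiproliferative activity, read by MTT assay, with a stated time of 72 h (on this read-out lower numbers stand for stronger inhibition and higher numbers for weaker inhibition), compound 2 gives 1090 nM as the only true number so far. Compound 1, which also has an aromatic ring on an amide-type nitrogen, reads > 50000 nM as a limit of the assay. Compound 3 `O=C(Nc1ccc(Cl)cc1)Nc1ccc(Nc2nccc(NC3CCCC3)n2)cc1` differs from compound 2 by one change, 4-chlorophenyl in place of cyclohexyl on an amide-type nitrogen. For the measured compounds named here, no measured step shows what such a swap does, so the hint from compound 1 is thin. A weakening beyond the scatter is expected in this assay, and the estimated step is a 2.8-fold higher number from compound 2 to compound 3 (0.44 log units; beyond the scatter) on this slim basis. The estimate for compound 3 is 3000 nM (expected range 500 nM to 20000 nM).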

Compound 3, half-maximal inhibitory concentration: 5310 nM
The estimate for compound 3 lay 1.8-fold (0.25 log units) below the measured number; the measured number falls inside the stated range.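

In this assay, among the compounds shown here, putting 4-chlorophenyl in place of cyclohexyl on an amide-type nitrogen gives a 4.9-fold higher number from compound 2 to compound 3 (0.69 log units; beyond the scatter), the first measured step at this position. This one aromatic ring weakens the compound, yet compound 3 still reads as a true number and not as a limit. The compounds shown offer no reason for this loss.

This single pair cannot separate the effect of the ring from that of its chlorine. On these data alone, how plain phenyl, or a ring carrying an amine such as piperidine, would behave at this position remains open.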